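A few compounds are considered here, and "the series" means these few. Any claim that something is new, unique, unknown or untested is made for them only; others in the source may bear on it.

Series notes. In a functional assay on BGC-823 cells (Homo sapiens) for cytotoxicity, read by CCK-8 assay, with a stated time of 24 h (a higher number here means a weaker inhibitor, a lower number a stronger inhibitor), compound 1 `C/C(=C\c1ccc(-c2ccc(C)cc2)o1)C(N)=O` returns only a limit, > 50000 nM, so no number is available for it. Compound 2 `C/C(=C\c1cccc(-c2ccccc2)c1)C(N)=O` likewise gives only a limit in this assay, > 50000 nM. Where compound 2 stands on the numbers shown therefore cannot be fixed more closely: both measured values sit at the limit of > 50000 nM in this assay, at which 2 of the 2 values shown sit, and no step between measured compounds can be worked out.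

Compound 3 `C/C(=C\c1cccc(-c2ccc(C)cc2)c1)C(N)=O` is not yet measured in this assay. It differs from compound 2 by methyl in place of hydrogen on an aromatic carbon, the change confined to the six-membered aromatic ring of carbon only. Compound 1 also bears a methyl on a six-membered aromatic ring of carbon only and gives > 50000 nM in this assay, a limit. Among the compounds with values here, nothing among the measured compounds points to a number appearing for compound 3. The expected step is a step that the limit leaves unreadable from compound 2 to compound 3, none beyond the scatter, with compound 3 most probably reported again as a limit. Compound 3 is estimated at 90000 nM, within 30000 nM to 400000 nM.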

Compound 3, half-maximal inhibitory concentration: > 50000 nM
Compound 3: a limit, no number; the forecaster's own chance of this, stated with the estimate: 90%; the middle value lies beyond the limit too.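

In this assay compound 3 gives > 50000 nM, a limit and not a number. The step from compound 2 to compound 3 cannot be read, since neither compound has a number, and all the compounds share one limit: the limit of > 50000 nM in this assay, at which 3 of the 3 values shown sit.

The compounds shown leave open whether any close relative of this series gives a number in this assay.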